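Swapping the nitrophenyl arm of compound 1

A few compounds are considered here, and "the series" means these few. Any claim that something is new, unique, unknown or untested is made for them only; others in the source may bear on it.

In a functional assay on SW 1116 cells (Homo sapiens) for cytotoxicity, read by MTT assay, with a stated time of 48 h (on this read-out lower numbers stand for stronger inhibition and higher numbers for weaker inhibition), three compounds have been measured so far:
Compound 1 `O=C(CSc1nnc(-c2ccncc2)o1)N/N=C/c1ccc([N+](=O)[O-])cc1` gives 25800 nM.
Compound 2 `COc1cccc(/C=N/NC(=O)CSc2nnc(-c3ccncc3)o2)c1` gives 16500 nM.
Compound 3 `COc1cc(/C=N/NC(=O)CSc2nnc(-c3ccncc3)o2)ccc1O` gives 3590 nM.

Compound 1 stands at the highest number of the three. Its nearest neighbour is compound 2, and that step stays within the scatter: a 1.6-fold lower number from compound 1 to compound 2 (0.19 log units; within the scatter). Compound 3 lies furthest away: a 7.2-fold lower number from compound 1 to compound 3 (0.86 log units; beyond the scatter). Between the two methoxy-bearing compounds the step is a 4.6-fold lower number from compound 2 to compound 3 (0.66 log units; beyond the scatter).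

Compound 4 `O=C(CSc1nnc(-c2ccncc2)o1)N/N=C/C=C/c1ccccc1` has not yet been measured. It differs from compound 1 in one place: 2-phenylethenyl in place of 4-nitrophenyl on a carbon with a double bond to nitrogen. Both measured steps that start from compound 1 also replace the group on that same carbon, and both lower the number, one within the scatter and one modestly beyond it. Within the data shown here, no measured compound carries a 2-phenylethenyl group, so there is no direct guide for this exact change. A small lowering, close to the edge of the scatter, is the expectation, giving an expected step of a 1.7-fold lower number from compound 1 to compound 4 (0.24 log units; within the scatter). Compound 4 is therefore expected to give about 15000 nM, within a range from 5000 nM to 40000 nM.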

Compound 4, half-maximal inhibitory concentration: 14900 nM
Estimate against measurement, compound 4: 1.0-fold (0.00 log units) above, and the stated range covers the measured number.
By their numbers in this assay, from the lowest: compound 3; then compounds 4, 2 and 1 (each within the scatter of the next).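

In this assay, 2-phenylethenyl, which holds only carbon and has no hydrogen-bond acceptors, lands level with both 4-nitrophenyl (a 1.7-fold lower number from compound 1 to compound 4 (0.24 log units; within the scatter)) and 3-methoxyphenyl (a 1.1-fold lower number from compound 2 to compound 4 (0.04 log units; within the scatter)), so on this carbon with a double bond to nitrogen, these three quite different groups cannot be told apart. Among these compounds, only 4-hydroxy-3-methoxyphenyl stands clearly apart from the new group (a 4.2-fold higher number from compound 3 to compound 4 (0.62 log units; beyond the scatter)), and compound 3 is the one compound of the four whose steps to all the others lie beyond the scatter. Nothing measured here accounts for this difference.

From the compounds shown here alone, it remains open whether a hydroxy group on the ring of 2-phenylethenyl would lower the number as it does from compound 2 to compound 3. Going by these compounds, the effect of an amine, a carboxylic acid or a longer chain at this place also remains unknown.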